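The compounds below may be only part of what the source reports. "The series", "measured", "known", "first", "only" and "open" are said of these compounds alone.

Compound 2 `O=C(O)c1ccc(-c2cnc(C(=O)CCCCCCc3ccccc3)o2)cc1` is the starting point of this step. In an assay (Rattus norvegicus) for inhibition of Fatty-acid amide hydrolase 1 (Homo sapiens) (a higher number here means a weaker inhibitor, a lower number a stronger inhibitor), compound 2 gives 60 nM, the second highest of the three numbers in hand. Compound 1 `COC(=O)c1cccc(-c2cnc(C(=O)CCCCCCc3ccccc3)o2)c1` gives 12 nM in this assay, a lower number that lies beyond the usual scatter. Compound 3 `O=C(CCCCCCc1ccccc1)c1ncc(-c2cnc(C(=O)CCCCCCc3ccccc3)o2)o1` gives 3500 nM in this assay, a far higher number, also well beyond the scatter. For the measured compounds named here, no pair of measured compounds differs in just one place, so no single measured step can guide the next move directly.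

The change to compound 4 `CN(C)C(=O)c1cnc(C(=O)CCCCCCc2ccccc2)o1` is dimethylcarbamoyl in place of 4-carboxyphenyl on an aromatic carbon. The aromatic group carrying the acid is removed and a small amide takes its place on the same ring carbon.

Since compound 3 3500 nM shows how much the number can climb when that position changes, and compound 2 60 nM already stands above compound 1, the step from compound 2 to compound 4 is expected to move toward a higher number, by a 5.0-fold higher number from compound 2 to compound 4 (0.70 log units; beyond the scatter), beyond the scatter. For compound 4 the value in this assay is estimated at 300 nM, with a range from 60 nM to 1500 nM.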

Compound 4, inhibition constant: 2 nM
Estimate against measurement, compound 4: 150-fold (2.18 log units) above, and the stated range ends above it.
By their numbers in this assay, from the lowest: compound 4; then compound 1; then compound 2; then compound 3.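

In this assay, for the compounds shown here, dimethylcarbamoyl in place of 4-carboxyphenyl on the aromatic carbon next to the ring oxygen gives a 30-fold lower number from compound 2 to compound 4 (1.48 log units; beyond the scatter), the only single-place step in hand. It shows that a six-membered aromatic ring is not needed at this position for a low number: the entering group has no ring and fewer heavy atoms, yet compound 4 gives 2 nM. No measurement here accounts for the size of this step.

The exchange removes the ring, the carboxylic acid and the hydrogen-bond donor in one move, so the compounds shown do not separate their contributions. On these data alone, it also remains open whether the number stays this low with a primary carboxamide, a piperidine amide or a small amine at this position.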